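Branched alkyl to oxolanylmethyl on the aryl ether oxygen

The source may hold more compounds than are shown below. What is called first, only, known or untested is meant among the compounds shown, and "the series" means these compounds.

Compound 1 `Nc1ccc2cccc(OCCC(F)(F)F)c2n1`: 722 nM
Compound 2 `CCOCCOc1cccc2ccc(N)nc12`: > 2000 nM
Compound 3 `CC(C)C(C)Oc1cccc2ccc(N)nc12`: 199 nM

In an assay on cells with melanin-concentrating hormone receptor 1 (Homo sapiens) as the target, read by radioligand binding (on this read-out higher numbers stand for weaker inhibition and lower numbers for stronger inhibition), compound 3 stands lowest of the two numbers, with a 3.6-fold lower number from compound 1 to compound 3 (0.56 log units; beyond the scatter) as the nearest comparison. The value of compound 2 is a limit of this assay (the limit of > 2000 nM in this assay, at which 1 of the 3 values shown sits). Compound 4 `Nc1ccc2cccc(OCC3CCOC3)c2n1` differs from compound 3 by (oxolan-3-yl)methyl in place of 1,2-dimethylpropyl on an oxygen on an aromatic ring. Within the data shown here, two steps bear on it: an at least 10-fold lower number from compound 2 to compound 3 (1.00 log units; beyond the scatter), where the 2-ethoxyethyl group, which also carries a hydrogen-bond acceptor, gave the limit, and an at least 2.7-fold higher number from compound 1 to compound 2 (0.44 log units; beyond the scatter). Both point toward a higher number when a hydrogen-bond acceptor enters the chain, so compound 4 is expected to show a 7.5-fold higher number from compound 3 to compound 4 (0.88 log units; beyond the scatter). The estimate for compound 4 is 1500 nM, between 400 nM and 5000 nM.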

Compound 4, half-maximal inhibitory concentration: 115 nM
Beside the measured number, compound 4's estimate is 13-fold (1.12 log units) above it; the whole stated range lies above it.
By their numbers in this assay, from the lowest: compounds 4 and 3 (each within the scatter of the next); then compound 1. At a limit, above all of these: compound 2.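

In this assay, a hydrogen-bond acceptor in the group on this oxygen does not by itself raise the number: a 1.7-fold lower number from compound 3 to compound 4 (0.24 log units; within the scatter), so (oxolan-3-yl)methyl and 1,2-dimethylpropyl cannot be told apart here. The ring-bearing group also improves on the fluorinated chain, with a 6.3-fold lower number from compound 1 to compound 4 (0.80 log units; beyond the scatter). Two oxygen-bearing groups can also differ widely, as an at least 17-fold lower number from compound 2 to compound 4 (1.24 log units; beyond the scatter) shows, though this step starts from a value of compound 2 that is a limit of the assay.

As far as these compounds go, what remains open is whether the ring oxygen matters at all, since cyclopentylmethyl would test that directly. From the compounds shown here alone, how a basic amine such as pyrrolidin-3-ylmethyl would fare on this oxygen also remains open.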